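Bromo for propyl on the shared core

The source may hold more compounds than are shown below. What is called first, only, known or untested is meant among the compounds shown, and "the series" means these compounds.

Of the compounds shown here, three have been measured in an assay on isolated protein for binding affinity to Alpha-2C adrenergic receptor (Homo sapiens); a lower number here means a stronger inhibitor, a higher number a weaker inhibitor. Compound 1 `c1ccc(OCC2=NCCN2)c(CC2CC2)c1` gives 631 nM; compound 2 `c1ccc(OC2CC2)c(OCC2=NCCN2)c1` gives 794 nM; compound 3 `CCCc1ccccc1OCC1=NCCN1` gives 490 nM. Compound 3 holds the lowest of the three numbers, but its gaps to the others are small: a 1.3-fold lower number from compound 1 to compound 3 (0.11 log units; within the scatter) and a 1.6-fold lower number from compound 2 to compound 3 (0.21 log units; within the scatter), both within the scatter, as is a 1.3-fold higher number from compound 1 to compound 2 (0.10 log units; within the scatter).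

Compound 4 `Brc1ccccc1OCC1=NCCN1` differs from compound 3 in one place: bromo in place of propyl on an aromatic carbon. All three measured steps exchange groups at this same position of the core, and none of them moved the number beyond the scatter. Among the measured compounds shown here, no measured step introduces a halogen, so the closest guide is that three different substituents at this position gave numbers close to one another. On that basis no step beyond the scatter is expected from compound 3 to compound 4, and the estimated change is a 1.0-fold higher number from compound 3 to compound 4 (0.01 log units; within the scatter). Compound 4 is therefore expected to give about 500 nM, with a range of 150 nM to 1600 nM.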

Compound 4, inhibition constant: 398 nM
Estimate against measurement, compound 4: 1.3-fold (0.10 log units) above; the range from low to high includes it.
By their numbers in this assay, from the lowest: compounds 4, 3, 1 and 2 (each within the scatter of the next).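

In this assay, a halogen at this position gives a number that stays within the scatter of a propyl group (a 1.2-fold lower number from compound 3 to compound 4 (0.09 log units; within the scatter)), so the assay does not separate a substituent of 1 heavy atom from one of 3 heavy atoms. Bromo also stays within the scatter of the two cyclopropyl-containing groups (a 1.6-fold lower number from compound 1 to compound 4 (0.20 log units; within the scatter); a 2.0-fold lower number from compound 2 to compound 4 (0.30 log units; within the scatter)), and the second of these steps, the largest in the set, extends the flat picture at this position to a halogen without leaving the scatter. Nothing available bears on why these four substituents give such close numbers.

Open, as far as these compounds go, is whether an amine, a carboxylic acid or a longer chain at this position would give a step beyond the scatter. Also open, from the compounds shown here alone, is whether fluoro, chloro or iodo would stay as close to bromo.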